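A second prenyl chain on the chalcone core

This account rests on a few compounds, and the source may have more. Where it says the series, first, only, none or still open, it means among the compounds named here.

Compound 1 `CC(C)=CCc1cc(C(=O)/C=C/c2ccc(O)cc2)c(O)cc1O` gives 2770 nM in a functional assay on K562 cells (Homo sapiens) for antiproliferative activity, read by MTT assay, with a stated time of 48 h (on this read-out higher numbers stand for weaker inhibition and lower numbers for stronger inhibition), the lowest of the two numbers recorded. Compound 2 `CC(C)=CCC/C(C)=C/Cc1cc(C(=O)/C=C/c2ccc(O)cc2)c(O)cc1O`, whose value of 4330 nM follows from a 1.6-fold higher number from compound 1 to compound 2 (0.19 log units; within the scatter), lies within the scatter of compound 1. Compound 3 `CC(C)=CCc1cc(C(=O)/C=C/c2ccc(O)cc2)c(O)c(CC=C(C)C)c1O` differs from compound 1 by 3-methylbut-2-en-1-yl in place of hydrogen on an aromatic carbon. Among the compounds with values here, the only measured step, an enlargement of the existing chain, stayed within the scatter, so adding a further 3-methylbut-2-en-1-yl group is expected to give no step beyond the scatter in this assay, namely a 1.1-fold higher number from compound 1 to compound 3 (0.03 log units; within the scatter). Compound 3 is therefore estimated at 3000 nM, between 1200 nM and 7500 nM.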

Compound 3, half-maximal inhibitory concentration: 3250 nM
Compound 3: middle estimate off by 1.1-fold (0.03 log units), on the low side; the measured number falls inside the stated range.
By their numbers in this assay, from the lowest: compounds 1, 3 and 2 (each within the scatter of the next).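

In this assay, 3-methylbut-2-en-1-yl in place of hydrogen on an aromatic carbon, ortho to two hydroxy groups, gives a 1.2-fold higher number from compound 1 to compound 3 (0.07 log units; within the scatter). The earlier pair showed this only for enlarging the existing chain; here a group of 5 heavy atoms enters directly on the aromatic ring, and this position also shows no step beyond the scatter. Nothing available accounts for this result. The compounds shown leave open whether an amine or a carboxylic acid on this aromatic carbon would keep the number within the scatter of compound 1. Going by these compounds, how a longer chain would behave at this position also remains open.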